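Swapping the aryl group on the core amine nitrogen

The source may hold more compounds than are shown below. What is called first, only, known or untested is meant among the compounds shown, and "the series" means these compounds.

Measured so far:
compound 1, `CCc1ccc(Nc2cc(NC(=O)Nc3cc(OC)cc(OC)c3)ncn2)cc1`, 23.5%
compound 2, `COc1ccc(F)cc1Nc1cc(NC(=O)Nc2c(Cl)cccc2Cl)ncn1`, 38.1%
compound 3, `Cc1cc(F)cc(Nc2cc(NC(=O)Nc3c(Cl)cccc3Cl)ncn2)c1`, 60.5%

These three compounds share a core and were tested in a functional assay on NCI-H520 cells (Homo sapiens) for inhibition, read by MTT assay, with a stated time of 48 h, tested at 10 uM; a lower number here means less inhibition, a higher number more inhibition at the concentration tested (going by the name of the read-out). Compound 1 gives the lowest number of the three: compound 2 is higher, and compound 3 is higher still, both by amounts beyond the usual scatter. Going by the values given here, the one single-site step among the measured compounds, a number 22.4 percentage points higher from compound 2 to compound 3 (beyond the scatter), exchanges the aryl group that sits on the nitrogen on an aromatic ring, the same place that changes here.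

Compound 4, `COc1cc(NC(=O)Nc2cc(Nc3cccc(C(C)(C)C)c3)ncn2)cc(OC)c1`, has not been measured yet. It differs from compound 1 in one place: 3-(tert-butyl)phenyl in place of 4-ethylphenyl on a nitrogen on an aromatic ring. The measured step gives only an indirect hint: it shows that swapping the aryl group at this nitrogen can move the read-out in this assay by a modest amount, but it involves different groups and a different urea partner, so it cannot fix the direction for the present change. With no closer comparison, compound 4 is expected to land near compound 1 or somewhat above it, a step of a number 6.5 percentage points higher from compound 1 to compound 4 (within the scatter), which may not exceed the scatter. The estimate for compound 4 is 30%, with a range from 12% to 52%.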

Compound 4, a percentage reported as inhibition, at one concentration (the size of the read-out at that concentration, not a potency): 13.1%
Compound 4: the middle estimate sits 16.9 percentage points above what was measured; measured number inside the range.
By their numbers in this assay, from the lowest: compound 4; then compound 1; then compound 2; then compound 3.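

In this assay, going by these compounds alone, replacing 4-ethylphenyl with 3-(tert-butyl)phenyl on the nitrogen gives a number 10.4 percentage points lower from compound 1 to compound 4 (beyond the scatter), the first step at this position with the dimethoxy-substituted urea partner of compound 1 held fixed. The earlier step at this nitrogen, a number 22.4 percentage points higher from compound 2 to compound 3 (beyond the scatter), went upward with a different urea partner, so this position can move the read-out in either direction, and exchanging one all-carbon aryl group for another, with no hydrogen-bond donors or acceptors on either, is enough to shift it beyond the scatter. Nothing shown gives a measured reason for the drop.

The group names show that two things change at once, the alkyl group and its numbered place on the ring, and the compounds shown do not separate these two changes. From the compounds shown here alone, it also remains open whether this step would carry over to the urea partner of compound 3, and how an amine or a carboxylic acid on this aryl ring would compare with the two alkyl groups.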